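Halogen step and a shortened chain in the series

A few compounds are considered here, and "the series" means these few. Any claim that something is new, unique, unknown or untested is made for them only; others in the source may bear on it.

compound 1 `COc1cc(NC(C)CCCNC(=O)NNC(=O)Nc2ccc(F)cc2)c2ncccc2c1` gives 310 nM in a functional assay on MCF7 cells (Homo sapiens) for inhibition, read by MTT assay, with a stated time of 72 h; on this read-out lower numbers stand for stronger inhibition and higher numbers for weaker inhibition
compound 2 `COc1cc(NC(C)CCCNC(=O)NNC(=O)Nc2ccc(Br)cc2)c2ncccc2c1` gives 100 nM in this assay

Compound 2 holds the lower of the two numbers in this assay and is reached by a modest step, a 3.1-fold lower number from compound 1 to compound 2 (0.49 log units; beyond the scatter) with bromo in place of fluoro on an aromatic carbon. Compound 3 `COc1cc(NC(C)CCCNC(=O)Nc2ccc(Cl)cc2)c2ncccc2c1` carries 4-chlorophenyl in place of ((4-bromophenyl)carbamoyl)amino on an amide-type nitrogen. The halogen step is the only measured one and bears only weakly on this larger change. For the measured compounds named here, no measured step covers the loss of the carbamoylamino unit, so direction and size remain tentative. A higher number is expected, with an estimated 8.0-fold higher number from compound 2 to compound 3 (0.90 log units; beyond the scatter) as the likely shift in this assay on this reading. The expected value for compound 3 is 800 nM with an estimated range from 150 nM to 5000 nM in this assay.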

Compound 3, half-maximal inhibitory concentration: 12000 nM
Beside the measured number, compound 3's estimate is 15-fold (1.18 log units) below it; the whole stated range lies below it.
By their numbers in this assay, from the lowest: compound 2; then compound 1; then compound 3.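

On the amide-type nitrogen, 4-chlorophenyl in place of ((4-bromophenyl)carbamoyl)amino in this assay gives a 120-fold higher number from compound 2 to compound 3 (2.08 log units; beyond the scatter), and the same exchange starting from the fluoro partner gives a 39-fold higher number from compound 1 to compound 3 (1.59 log units; beyond the scatter). Among these three compounds, the large steps therefore lie at this position and not in the halogen exchange, so the ((4-halophenyl)carbamoyl)amino unit cannot be lost here without a large rise in the number. No measurement on hand accounts for this rise.

The compounds shown do not separate the loss of the carbamoylamino unit from the arrival of chloro on the aromatic ring. Going by these compounds, whether 4-bromophenyl on this same nitrogen, or an amine or a carboxylic acid on the terminal phenyl ring, would bring the number back down remains open.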